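Propylsulfonyl to ethylsulfonyl on the shared core

The source may report more compounds than this note shows. Statements on the series, on what has been measured and on what is new or still open speak of the compounds shown alone.

Compound 2 `CCCS(=O)(=O)Nc1cccc2c1CCC2c1ncc[nH]1` was measured in a functional assay on CHO cells for agonist activity at Alpha-1A adrenergic receptor (Homo sapiens), read by FLIPR and calcium flux (a lower number here means that less compound is needed, a higher number that more compound is needed for the effect), at 1340 nM. Of the two single numbers in this assay, compound 2 gives the highest one; compound 1 `COc1c(C)ccc2c1CCC2c1ncc[nH]1` gives 167 nM, a lower number by a margin beyond the scatter. Compound 3 `CS(=O)(=O)Nc1cccc2c1CCCC2c1ncc[nH]1` is the further entry without a single number: in this assay compound 3 has several values, 2150 nM; 142 nM; 234 nM (3 entries), and the spread among them the several entries of compound 3 in this assay, 2150 nM; 142 nM; 234 nM (3 entries) is wide, so any single number in this series should be read with caution.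

Compound 4 `CCS(=O)(=O)Nc1cccc2c1CCC2c1ncc[nH]1` is not yet measured in this assay. It differs from compound 2 as follows: hydrogen in place of methyl on a saturated chain carbon, two bonds along the chain from a sulfonyl sulfur. Among the measured compounds shown here, no step between two measured compounds of this kind exists, so its size is not known from the data. The change is expected to give a step from compound 2 of a 1.3-fold lower number from compound 2 to compound 4 (0.13 log units; within the scatter) in this assay, that is, no movement beyond the scatter in either direction. Compound 4 is therefore estimated in this assay at 1000 nM, with a range from 250 nM to 4000 nM.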

Compound 4, half-maximal effective concentration: 32 nM
The estimate for compound 4 lay 31-fold (1.49 log units) above the measured number; measured number outside the range, below it.
By their numbers in this assay, from the lowest: compound 4; then compound 1; then compound 2.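

Propylsulfonyl to ethylsulfonyl is the only step in the series that can be read at this position, and in this assay it gives a 42-fold lower number from compound 2 to compound 4 (1.62 log units; beyond the scatter). A single methyl, on a saturated chain carbon, two bonds along the chain from a sulfonyl sulfur, is therefore enough to move the number well beyond the scatter, so this end of the chain is not a place where the read-out stays flat. The exact size of the step calls for caution, because repeat values for one compound in this assay spread widely: the several entries of compound 3 in this assay, 2150 nM; 142 nM; 234 nM (3 entries)

On these data alone, whether a longer chain such as butylsulfonyl, or a shorter one such as methylsulfonyl on this same core, continues the trend remains open. This single pair also leaves open whether the step would hold on a different core.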